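The source may report more compounds than this note shows. Statements on the series, on what has been measured and on what is new or still open speak of the compounds shown alone.

Working notes on the series. In a functional assay (Homo sapiens) for inhibition of Nucleic Acid, tested at 100 uM (on this read-out higher numbers stand for more inhibition at the one concentration tested (going by the name of the read-out) and lower numbers for less inhibition), compound 1 `Nc1[nH]ccc2ncnc1-2` gives 60%, while compound 2 `CCNc1[nH]ccc2ncnc1-2` gives 3%, the lowest of the two numbers recorded so far, with compound 1 its nearest neighbour. For the measured compounds named here, the one measured step, a number 57 percentage points lower from compound 1 to compound 2 (beyond the scatter), followed ethyl in place of hydrogen on a nitrogen on an aromatic ring. Compound 3 `CSc1[nH]ccc2ncnc1-2` differs from compound 2 by methylsulfanyl in place of ethylamino on an aromatic carbon. Going by the values given here, no measured step carries this change; only compound 1 hints that a hydrogen-bond donor at this position matters, and methylsulfanyl has none. The step is therefore expected to stay near the scatter, as a number 12 percentage points higher from compound 2 to compound 3 (beyond the scatter). Compound 3 is estimated at 15%, between 0% and 45%.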

Compound 3, a percentage reported as inhibition, at one concentration (the size of the read-out at that concentration, not a potency): 4%
Compound 3: the middle estimate sits 11 percentage points above what was measured; measured number inside the range.
By their numbers in this assay, from the lowest: compounds 2 and 3 (each within the scatter of the next); then compound 1.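

Methylsulfanyl in place of ethylamino on this aromatic carbon gives a number 1 percentage points higher from compound 2 to compound 3 (within the scatter) and so reads no differently from ethylamino. Methylsulfanyl in place of amino gives a number 56 percentage points lower from compound 1 to compound 3 (beyond the scatter) and shows that the drop seen with ethylamino is not confined to that one group; of the three groups shown, only amino, in compound 1, retains substantial inhibition. No evidence on hand bears on this result.

Still open, as far as these compounds go, is whether hydroxyl or methylamino at this aromatic carbon would keep the number of compound 1 or fall to the level of compound 2 and compound 3.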